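Piperazine nitrogen substituent change on the shared core

The source may hold more compounds than are shown below. What is called first, only, known or untested is meant among the compounds shown, and "the series" means these compounds.

The series shares the core of compound 1 `N#Cc1ccc(Nc2nc(Oc3ccnc4ccccc34)nc(N3CCCCC3)n2)cc1C(F)(F)F`. In a functional assay on DU-145 cells (Homo sapiens) for cytotoxicity, read by sulforhodamine B assay, with a stated time of 48 h (on this read-out higher numbers stand for weaker inhibition of growth and lower numbers for stronger inhibition of growth), compound 1 gives > 100000 nM, which is a limit of the assay and not a number. Compound 2 `CC(=O)N1CCN(c2nc(Nc3ccc(C#N)c(C(F)(F)F)c3)nc(Oc3ccnc4ccccc34)n2)CC1` carries 4-acetylpiperazin-1-yl in place of piperidin-1-yl on an aromatic carbon; the step that the two limits leave unreadable from compound 1 to compound 2 cannot be read because both values sit at the limit of > 100000 nM in this assay, at which 3 of the 3 values shown sit. In this assay compound 2 gives > 100000 nM, again a limit. Compound 3 `N#Cc1ccc(Nc2nc(Oc3ccnc4ccccc34)nc(N3CCN(C(c4ccccc4)c4ccc(Cl)cc4)CC3)n2)cc1C(F)(F)F` gives > 100000 nM in this assay, also a limit. For the measured compounds named here, compound 2 thus stands at the limit, as do the two further values shown, and no compound separates from another.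

Compound 4 `N#Cc1ccc(Nc2nc(Oc3ccnc4ccccc34)nc(N3CCN(c4ccc(F)cc4)CC3)n2)cc1C(F)(F)F` differs from compound 2 by 4-fluorophenyl in place of acetyl on an amine nitrogen in a ring. Going by the values given here, no readable measured step bears on this change; the only measured step is unreadable. No step beyond the scatter is therefore expected in this assay, in either direction. Compound 4 is expected at 150000 nM, within 40000 nM to 600000 nM, most likely reported once more as a limit. The expected step that the limit leaves unreadable from compound 2 to compound 4 is estimated as nothing beyond the scatter.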

Compound 4, concentration for total growth inhibition: > 100000 nM
Compound 4 ended at the assay's limit; the forecaster's own chance of this, stated with the estimate: 75%; the middle value is on the limit's open side.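

The step from compound 2 to compound 4 cannot be read, as both values are limits of the assay and not numbers: the limit of > 100000 nM in this assay, at which 4 of the 4 values shown sit.

The compounds shown leave open whether any group on the amine nitrogen in the ring gives a readable value in this assay.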